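The compounds below may be only part of what the source reports. "The series", "measured", "known", "first", "only" and "open" are said of these compounds alone.

Among the measured compounds shown here, compound 2 `COCC(=O)NCCCCCC(=O)N[C@H](C(=O)N1C[C@H](O)C[C@H]1C(=O)NCc1ccc(-c2scnc2C)cc1)C(C)(C)C` gives 126% in an ADME assay on a cell-free system (plasma, Homo sapiens) for metabolic stability, with a stated time of 90 min (on this read-out lower numbers stand for a less stable compound and higher numbers for a more stable compound), the highest of the two numbers so far. Compound 1 `CCCC(=O)NCCCCCC(=O)N[C@H](C(=O)N1C[C@H](O)C[C@H]1C(=O)NCc1ccc(-c2scnc2C)cc1)C(C)(C)C` gives 83% in this assay, and the step of a number 43 percentage points higher from compound 1 to compound 2 (beyond the scatter) is the only measured one. Compound 3 `Cc1ncsc1-c1ccc(CNC(=O)[C@@H]2C[C@@H](O)CN2C(=O)[C@@H](NC(=O)CCCCCNC(=O)C2CCCCC2)C(C)(C)C)cc1` differs from compound 2 by cyclohexyl in place of methoxymethyl on a carbonyl carbon. That single step ran from ethyl to methoxy, whereas here methoxymethyl leaves and cyclohexyl enters, so a fall beyond the scatter is expected, roughly a number 41 percentage points lower from compound 2 to compound 3 (beyond the scatter). Compound 3 is therefore estimated at 85%, with a range from 60% to 110%.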

Compound 3, percent of the compound remaining: 168%
The estimate for compound 3 lay 83 percentage points below the measured number; the measured number lies above the stated range.
By their numbers in this assay, from the lowest: compound 1; then compound 2; then compound 3.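

On a carbonyl carbon whose other neighbour is an amide-type nitrogen, cyclohexyl gives the highest number of the three in this assay, with a number 42 percentage points higher from compound 2 to compound 3 (beyond the scatter) against methoxymethyl and a number 85 percentage points higher from compound 1 to compound 3 (beyond the scatter) against propyl. A ring of carbon only therefore outperforms both open chains here, so an oxygen in this group is not needed for a high number. Nothing available explains this order.

On these data alone, whether the ring itself matters remains open, since cyclopentyl, phenyl or a longer carbon chain could separate ring from size. An amine or a carboxylic acid at this place is also untested in the compounds shown.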